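The source may report more compounds than this note shows. Statements on the series, on what has been measured and on what is new or still open speak of the compounds shown alone.

Two compounds of the series have been run so far. Compound 1 `CC(=O)Nc1ccc(OCC(=O)NNC(=S)NCc2ccccc2)cc1` in a toxicity assay on MT4 cells (Homo sapiens) for cytotoxicity, read by MTT assay, with a stated time of 5 days (a higher number here means that more compound is tolerated, a lower number that less compound is tolerated), gives 83.5 ug/mL. Compound 2 `Cc1ccc(C(C)C)c(OCc2nnc(SCC(=O)Nc3ccc(Cl)cc3)n2Cc2ccccc2)c1` in this assay gives 65.9 ug/mL. Compound 2 is the lower of the two numbers, and its nearest neighbour is compound 1; the gap between the two values lies within the scatter of repeated measurements, so the two compounds are not separated by this assay. For the measured compounds named here, no step between measured compounds is available from which to read off the effect of a substituent change.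

The next compound, compound 3 `Cc1ccc(C(C)C)c(OCc2nnc(SCC(=O)Nc3ccc([N+](=O)[O-])cc3)n2Cc2ccccc2)c1`, differs from compound 2 in one place: nitro in place of chloro on an aromatic carbon. Going by the values given here, nothing measured speaks to this exchange, and the only two numbers in hand sit together within the scatter. The step from compound 2 to compound 3 in this assay is therefore expected to be small, a 1.1-fold lower number from compound 2 to compound 3 (0.04 log units; within the scatter), with no direction that can be argued for beyond the scatter. Compound 3 is estimated at 60 ug/mL, with a range from 30 ug/mL to 120 ug/mL.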

Compound 3, half-maximal cytotoxic concentration: 11.2 ug/mL
Estimate against measurement, compound 3: 5.4-fold (0.73 log units) above; the whole stated range lies above it.
By their numbers in this assay, from the lowest: compound 3; then compounds 2 and 1 (each within the scatter of the next).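

In this assay, for the compounds shown here, the exchange of 4-chlorophenyl for 4-nitrophenyl gives a 5.9-fold lower number from compound 2 to compound 3 (0.77 log units; beyond the scatter), the only step so far and one that lies beyond the scatter. This aromatic carbon, para to a large group, is therefore not a silent place in this assay: with the rest of the structure unchanged, nitro, with 3 heavy atoms and 2 hydrogen-bond acceptors, in place of chloro, with 1 heavy atom and no hydrogen-bond acceptor, goes with less compound being tolerated. No measurement at hand bears on what lies behind this step.

Going by these compounds, with a single exchange at this place, it remains open whether the lower number is specific to nitro or would also appear with another group on the same carbon, such as an amine, a carboxylic acid or a methoxy group. Also open, on these data alone, is whether the step would keep its size if the (4-nitrophenyl)carbamoyl part were attached through a longer chain, or whether it belongs only to the shared core of compound 2 and compound 3.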